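Swapping pyrrolidin-1-yl for 1H-imidazol-1-yl in compound 3

The source may report more compounds than this note shows. Statements on the series, on what has been measured and on what is new or still open speak of the compounds shown alone.

Compound 1 `CC(=O)N(C)C(C)C#CCn1ccnc1` gives > 100 mg/kg as a limit of the assay
Compound 2 `CCOC(=O)N(C)CC#CCn1ccnc1` gives 97 mg/kg
Compound 3 `CCOC(=O)N(C)C(C)C#CCN1CCCC1` gives 97 mg/kg

In a functional assay on the whole organism for antagonist activity, with Mus musculus as the target (on this read-out higher numbers stand for an effect only at larger amounts of compound and lower numbers for an effect already at smaller amounts), compound 3 gives 97 mg/kg and stands level with compound 2 at 97 mg/kg within the scatter. Compound 1 reaches only a limit of the assay at > 100 mg/kg and no number.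

The next compound is compound 4 `CCOC(=O)N(C)C(C)C#CCn1ccnc1`. Compound 4 carries 1H-imidazol-1-yl in place of the pyrrolidin-1-yl of compound 3 on a saturated chain carbon bound to a triple-bonded carbon. The full count of that change reads 1H-imidazol-1-yl in place of pyrrolidin-1-yl on a saturated chain carbon bound to a triple-bonded carbon here.

Among the measured compounds shown here, no two measured compounds differ in one place only, so the expectation rests on their values alone. Compound 2 already carries 1H-imidazol-1-yl and gives 97 mg/kg in this assay, while compound 3 carries pyrrolidin-1-yl and gives 97 mg/kg there. A value for compound 4 close to these two is therefore expected. The expected step is a 1.1-fold lower number from compound 3 to compound 4 (0.03 log units; within the scatter) in this assay and no change beyond the scatter is expected. Compound 4 is estimated at 90 mg/kg with an expected range from 45 mg/kg to 190 mg/kg in this assay for now.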

Compound 4, dose for half-maximal effect: 54 mg/kg
For compound 4 the middle estimate is 1.7-fold (0.22 log units) above the measured one; low and high end bracket the measured number.
By their numbers in this assay, from the lowest: compounds 4, 2 and 3 (each within the scatter of the next). At a limit, above all of these: compound 1.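

In this assay, among the compounds shown here, 1H-imidazol-1-yl in place of pyrrolidin-1-yl on a saturated chain carbon bound to a triple-bonded carbon gives a 1.8-fold lower number from compound 3 to compound 4 (0.25 log units; within the scatter), so this exchange of one five-membered ring for the other, read alone for the first time, does not move the number beyond the scatter. Methyl in place of hydrogen on a saturated chain carbon bound to an amide-type nitrogen and a triple-bonded carbon gives a 1.8-fold lower number from compound 2 to compound 4 (0.25 log units; within the scatter), so this methyl does not move it beyond the scatter either. Ethoxy in place of methyl on a carbonyl carbon gives an at least 1.8-fold lower number from compound 1 to compound 4 (0.26 log units; that floor lies within the scatter), and this step is only a floor, since compound 1 stands at a limit and not at a number: the limit of > 100 mg/kg in this assay, at which 1 of the 4 values shown sits.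

As far as these compounds go, it remains open whether another group on the saturated chain carbon bound to a triple-bonded carbon, such as piperidin-1-yl or dimethylamino, would take the number beyond the scatter, and whether ethyl in place of that methyl would do so. From the compounds shown here alone, on the carbonyl carbon, the effect of a longer chain such as butoxy also remains open, as does the true size of the ethoxy step.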